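A tert-butoxy change on compound 1

This account rests on a few compounds, and the source may have more. Where it says the series, first, only, none or still open, it means among the compounds named here.

Measured so far in an ADME assay on Caco-2 cells (Homo sapiens) for permeability, read by LC-MS, in the apical to basolateral direction, with a stated time of 60 min, at pH 6.5; a lower number here means that the compound crosses the layer more slowly, a higher number that the compound crosses the layer faster:
- compound 1 `O=C(NCc1cc(Cl)ccc1-n1cnnn1)[C@@H]1C[C@@H]2C[C@@H]2N1C(=O)[C@H](O)CC1CC1` (3.6 10^-6 cm/s)
- compound 2 `Cc1cccc([C@@H](O)C(=O)N2N=CC[C@H]2C(=O)NCc2cc(Cl)ccc2-n2cnnn2)c1` (9.7 10^-6 cm/s)

Of these two compounds, compound 1 has the lower number (3.6 10^-6 cm/s). Compound 2 reads higher (9.7 10^-6 cm/s), and that gap lies beyond the usual scatter. The two compounds differ in more than one place, however, so their gap says nothing about any single change.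

The next compound is compound 3 `CC(C)(C)OC[C@@H](O)C(=O)N1[C@H](C(=O)NCc2cc(Cl)ccc2-n2cnnn2)C[C@@H]2C[C@@H]21`, which keeps the core of compound 1. Its change is tert-butoxy in place of cyclopropyl on a saturated chain carbon, two bonds along the chain from a carbonyl carbon and an oxygen on a saturated carbon. Going by the values given here, no measured pair shows what this change does in this assay, so the expectation starts from compound 1 (3.6 10^-6 cm/s) and assumes no shift beyond the scatter in either direction. The expected step is small and estimated as a 1.3-fold higher number from compound 1 to compound 3 (0.10 log units; within the scatter) (an estimate, not a measurement). For compound 3 the estimated value is 4.5 10^-6 cm/s (expected range 1.8 10^-6 cm/s to 11 10^-6 cm/s).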

Compound 3, apparent permeability: 4.5 10^-6 cm/s
For compound 3 middle estimate and measured number coincide at the digits printed; low and high end bracket the measured number.
By their numbers in this assay, from the lowest: compounds 1 and 3 (each within the scatter of the next); then compound 2.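

Going by these compounds alone, compounds 1 and 3 form the first pair that differs in one place, so this position can now be read on its own. In this assay, replacing cyclopropyl with tert-butoxy on a saturated chain carbon, two bonds along the chain from a carbonyl carbon and an oxygen on a saturated carbon, gives a 1.3-fold higher number from compound 1 to compound 3 (0.10 log units; within the scatter). On the core of compound 1, then, this position accepts a group with two more heavy atoms, no ring and one hydrogen-bond acceptor without the number moving beyond the scatter, although no measurement here offers any explanation for that outcome.

This single pair leaves open whether an amine, a carboxylic acid or a longer carbon chain at the same position would also keep the number within the scatter, or would instead move it in this assay. It also leaves open whether the same exchange would behave alike on the core of compound 2, and which of the several differences separating compound 2 from the other two compounds accounts for its higher number.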